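Carboxy to Carbamoyl on a Shared Core: An Estimate

This account rests on a few compounds, and the source may have more. Where it says the series, first, only, none or still open, it means among the compounds named here.

Measured compounds:
compound 1 `COc1ncc(-c2ccc3ncc(C(=O)O)n3c2)cc1NS(=O)(=O)c1ccc(F)cc1F` gives 370 nM
compound 2 `COc1ncc(-c2ccc3ncc(C(=O)N4CCC(OC(=O)c5ccccc5)CC4)n3c2)cc1NS(=O)(=O)c1ccc(F)cc1F` gives 1450 nM
compound 3 `CCCCS(=O)(=O)Nc1cc(-c2ccc3ncc(C(=O)OCC)n3c2)cnc1OC` gives 2320 nM

These three were tested in a functional assay on MDA-MB-231 cells (Homo sapiens) for antiproliferative activity, read by sulforhodamine B assay, with a stated time of 72 h; a higher number here means a weaker inhibitor, a lower number a stronger inhibitor. Compound 1 carries the lowest number of the three, with compound 2 and compound 3 both lying beyond the usual scatter above it. Compound 4 `COc1ncc(-c2ccc3ncc(C(=O)NCc4ccncc4)n3c2)cc1NS(=O)(=O)c1ccc(F)cc1F` has not yet been measured. It differs from compound 1 in one place: ((pyridin-4-yl)methyl)amino in place of hydroxy on a carbonyl carbon. Among the measured compounds shown here, no directly comparable step between measured compounds exists for this change, so the expected size must be judged loosely. Since compound 2, which also replaces the carboxy hydroxy with a nitrogen-linked group, gives 1450 nM, a moderate weakening is expected for compound 4, a step of a 2.2-fold higher number from compound 1 to compound 4 (0.33 log units; beyond the scatter). Compound 4 is therefore estimated at 800 nM, within a range from 250 nM to 2500 nM.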

Compound 4, half-maximal inhibitory concentration: 420 nM
Compound 4: middle estimate off by 1.9-fold (0.28 log units), on the high side, within the range that was stated.
By their numbers in this assay, from the lowest: compounds 1 and 4 (each within the scatter of the next); then compounds 2 and 3 (each within the scatter of the next).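

In this assay, putting ((pyridin-4-yl)methyl)amino in place of hydroxy on the carbonyl carbon gives a 1.1-fold higher number from compound 1 to compound 4 (0.06 log units; within the scatter). This place on the shared core therefore takes a much larger group carrying an aromatic ring, with no difference that stands out from the scatter, and the carboxy group is not needed to keep a number at this level. Nothing available explains why the two values match.

Going by these compounds, whether the ring nitrogen matters stays open. Benzylamino or plain methylamino on the same carbonyl carbon would separate the contribution of the ring and its nitrogen from that of the amide itself.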